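The compounds below may be only part of what the source reports. "The series", "measured", "known", "first", "only" and "open" are said of these compounds alone.

Measured compounds:
compound 1, `COc1cccc(N2CCN(c3ccc(C(=O)/C=C/c4ccccc4)cc3)CC2)c1`: 16%
compound 2, `O=C(/C=C/c1ccc(Cl)cc1)c1ccc(N2CCN(c3cccc(Cl)c3)CC2)cc1`: 5.85%
compound 3, `COc1cccc(N2CCN(c3ccc(C(=O)/C=C/c4ccc(Cl)cc4)cc3)CC2)c1`: 2.28%

These three compounds share one core and were tested in a functional assay on the whole organism (strain Kunming) for inhibition, with Mus musculus as the target, with a stated time of 1 h, at a dose of 40 mg/kg by the oral route; a lower number here means less inhibition, a higher number more inhibition at the dose given (going by the name of the read-out). Compound 1 stands highest of the three, and its lead over both compound 2 and compound 3 is beyond the scatter. The two measured steps are small in kind: a number 13.7 percentage points lower from compound 1 to compound 3 (beyond the scatter), and a number 3.6 percentage points lower from compound 2 to compound 3 (within the scatter).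

Compound 4, `O=C(/C=C/c1ccccc1)c1ccc(N2CCN(S(=O)(=O)c3ccc(Cl)cc3)CC2)cc1`, has not yet been measured. It differs from compound 1 as follows: (4-chlorophenyl)sulfonyl in place of 3-methoxyphenyl on an amine nitrogen in a ring. This is a larger alteration than either measured step, and it sits at a different place, the amine nitrogen in the ring rather than an aromatic carbon. Going by the values given here, no measured step therefore tests this exchange directly. Among the compounds with values here, the only guidance is indirect: a change on the ring attached to that nitrogen, methoxy for chloro, gave a number 3.6 percentage points lower from compound 2 to compound 3 (within the scatter), so the number stayed level within the scatter when this part of the molecule was varied. Since every measured number is low, an expectation near compound 1 with wide uncertainty seems fair. For compound 4 in this assay the estimate is 10%, with a range from 0% to 30%, meaning an expected step of a number 6 percentage points lower from compound 1 to compound 4 (within the scatter).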

Compound 4, a percentage reported as inhibition, in the whole organism at one dose (the size of the read-out at that dose, not a potency): 46.8%
Compound 4: the middle estimate sits 36.8 percentage points below what was measured, and the stated range ends below it.
By their numbers in this assay, from the lowest: compounds 3 and 2 (each within the scatter of the next); then compound 1; then compound 4.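

In this assay, going by these compounds alone, putting (4-chlorophenyl)sulfonyl in place of 3-methoxyphenyl on the amine nitrogen in the ring gives a number 30.8 percentage points higher from compound 1 to compound 4 (beyond the scatter), the only step in this set that raises the number, and a large one. The earlier steps shown here each swapped one small substituent on an aromatic carbon, and none of them showed that the group on this nitrogen could move the read-out so far. What enters here keeps one six-membered aromatic ring but joins it to the nitrogen through a sulfonyl group, and no measurement at hand accounts for the rise.

This single step changes two things at once, the sulfonyl group attached to the nitrogen and the substituent on the aromatic ring, so the compounds shown cannot say which of them matters or whether both are needed. A phenylsulfonyl group without the chlorine would test the role of the chlorine, while a benzoyl or methanesulfonyl group on the same nitrogen would show how far the rise depends on the sulfonyl group and on the aromatic ring.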